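A few compounds are considered here, and "the series" means these few. Any claim that something is new, unique, unknown or untested is made for them only; others in the source may bear on it.

Working notes on the series. Compound 3 `O=C(NC1CC1)[C@H]1O[C@@H](n2cnc3c(NCc4cccc(I)c4)nc(Cl)nc32)[C@H](O)[C@@H]1O` gives 2.95 nM in an assay on CHO cells for displacement of a labelled ligand from adenosine receptor A3 (Homo sapiens) (on this read-out lower numbers stand for stronger inhibition and higher numbers for weaker inhibition), and stands second highest of the three numbers, nearest to compound 1 `CNc1nc(Cl)nc2c1ncn2[C@@H]1O[C@H](C(=O)NC2CC2)[C@@H](O)[C@H]1O` with 2.82 nM, furthest from compound 2 `O=C(NC1CC1)[C@H]1O[C@@H](n2cnc3c(NC4CC4)nc(Cl)nc32)[C@H](O)[C@@H]1O` with 5.62 nM; all three lie within the scatter of one another, as the steps of a 2.0-fold higher number from compound 1 to compound 2 (0.30 log units; within the scatter), a 1.0-fold higher number from compound 1 to compound 3 (0.02 log units; within the scatter) and a 1.9-fold lower number from compound 2 to compound 3 (0.28 log units; within the scatter) show. Compound 4 `O=C(NC1CCC1)[C@H]1O[C@@H](n2cnc3c(NCc4cccc(I)c4)nc(Cl)nc32)[C@H](O)[C@@H]1O` differs from compound 3 by cyclobutyl in place of cyclopropyl on an amide-type nitrogen. Within the data shown here, none of the measured steps touches the amide-type nitrogen; each of them alters the group on the nitrogen on the aromatic ring, and all stay within the scatter. Among the measured compounds shown here, no measured step therefore bears directly on this change, and the series gives no ground to expect more than a small step in this assay. Compound 4 is estimated at 6 nM, with a range from 2 nM to 20 nM, which means an expected step of a 2.0-fold higher number from compound 3 to compound 4 (0.31 log units; beyond the scatter).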

Compound 4, inhibition constant: 18.2 nM
Compound 4: the middle estimate sits 3.0-fold (0.48 log units) below what was measured; the range from low to high includes it.
By their numbers in this assay, from the lowest: compounds 1, 3 and 2 (each within the scatter of the next); then compound 4.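

Among these compounds, the amide-type nitrogen is the first place where a single change moves the number in this assay beyond the scatter: cyclobutyl in place of cyclopropyl gives a 6.2-fold higher number from compound 3 to compound 4 (0.79 log units; beyond the scatter). The changes on the nitrogen on the aromatic ring all stayed within the scatter, whereas here a ring larger by one carbon is enough. Nothing at hand accounts for this step.

On these data alone, whether a cyclopentyl or an ethyl on the amide-type nitrogen follows cyclobutyl or cyclopropyl remains open. So does whether the step holds with methylamino instead of 3-iodobenzylamino on the aromatic ring.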